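The source may report more compounds than this note shows. Statements on the series, on what has been measured and on what is new or still open speak of the compounds shown alone.

In an assay on the whole organism (plasma, strain Sprague-Dawley) for inhibition of Dipeptidyl peptidase 4 (Rattus norvegicus), with a stated time of 6 h, at a dose of 1 mg/kg by the oral route (on this read-out lower numbers stand for less inhibition and higher numbers for more inhibition at the one dose given (going by the name of the read-out)), compound 2 `CCCNC(=O)[C@@H]1CN[C@H](C(=O)N2CCC[C@H]2C#N)C1` gives 59%, the lowest of the two numbers shown, though within the scatter of compound 1 `N#C[C@@H]1CCCN1C(=O)[C@@H]1C[C@H](C(=O)N2CCCCCCC2)CN1`, which gives 63%. Compound 3 `N#C[C@@H]1CCCN1C(=O)[C@@H]1C[C@H](C(=O)N2CCCCC2)CN1` is not yet measured; it differs from compound 2 by piperidin-1-yl in place of propylamino on a carbonyl carbon. Among the compounds with values here, the one measured step bearing on this change is a number 4 percentage points lower from compound 1 to compound 2 (within the scatter), where a ring-bearing amide gave way to propylamino without moving beyond the scatter. Going back to a ring-bearing amide is therefore expected to move little, a number 3 percentage points higher from compound 2 to compound 3 (within the scatter). Compound 3 is estimated to give 62% in this assay, with a range from 50% to 74%.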

Compound 3, a percentage reported as inhibition, in the whole organism at one dose (the size of the read-out at that dose, not a potency): 84%
Estimate against measurement, compound 3: 22 percentage points below; measured number above the stated range.
By their numbers in this assay, from the lowest: compounds 2 and 1 (each within the scatter of the next); then compound 3.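

At this carbonyl carbon, this assay clearly responds to the group carried, with a number 25 percentage points higher from compound 2 to compound 3 (beyond the scatter) when piperidin-1-yl replaces propylamino. A ring alone does not set compound 3 apart, as the step to the six-membered ring from the eight-membered one is a number 21 percentage points higher from compound 1 to compound 3 (beyond the scatter) and compound 1 remains within the scatter of compound 2. Nothing measured here explains this rise. Going by these compounds, whether the higher number belongs to the six-membered ring alone remains open. The compounds shown do not tell how pyrrolidin-1-yl or morpholin-4-yl would read on this carbonyl carbon.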